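Ethyl in Place of 5-Fluoro-2-methoxyphenyl on the Ring Nitrogen

The compounds below may be only part of what the source reports. "The series", "measured", "known", "first", "only" and "open" are said of these compounds alone.

Compound 1 `COc1ccc(OC)c(N2C(=O)CSC2c2cccc(C(=O)NCCCCc3ccccc3)c2)c1` gives 5%.
Compound 2 `COc1ccc(F)cc1N1C(=O)CSC1c1cccc(C(=O)NCCCCc2ccccc2)c1` gives 46%.

In a functional assay on HOS cells (Homo sapiens) for inhibition, read by CCK-8 assay, with a stated time of 72 h, tested at 1 uM (on this read-out lower numbers stand for less inhibition and higher numbers for more inhibition at the one concentration tested (going by the name of the read-out)), compound 2 stands highest of the two measured numbers, with compound 1 as the only other point. Among the compounds with values here, the one known step, a number 41 percentage points higher from compound 1 to compound 2 (beyond the scatter), shows that a single change on the group sitting on the amide-type nitrogen in a ring can shift the read-out strongly. Compound 3 `CCN1C(=O)CSC1c1cccc(C(=O)NCCCCc2ccccc2)c1` carries a different change: ethyl in place of 5-fluoro-2-methoxyphenyl on an amide-type nitrogen in a ring. Within the data shown here, no measured step replaces that whole ring with a short chain, so the known step bears on it only loosely. The read-out is expected to drop, an estimated a number 26 percentage points lower from compound 2 to compound 3 (beyond the scatter). Compound 3 is therefore estimated at 20%, between 0% and 50%.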

Compound 3, a percentage reported as inhibition, at one concentration (the size of the read-out at that concentration, not a potency): 6%
Estimate against measurement, compound 3: 14 percentage points above; measured number inside the range.
By their numbers in this assay, from the lowest: compounds 1 and 3 (each within the scatter of the next); then compound 2.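

In this assay, the change to ethyl gives a number 40 percentage points lower from compound 2 to compound 3 (beyond the scatter) and so removes most of the inhibition seen with 5-fluoro-2-methoxyphenyl on this ring nitrogen. Ethyl in place of 2,5-dimethoxyphenyl gives a number 1 percentage points higher from compound 1 to compound 3 (within the scatter), so an aromatic ring at this position is not enough on its own, and the groups on that ring matter. The data shown offer no measured explanation for this difference.

Still open, going by these compounds, is how a plain phenyl ring would behave at this position. On these data alone, it is also open whether a longer chain, such as butyl, would behave like ethyl.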